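This account rests on a few compounds, and the source may have more. Where it says the series, first, only, none or still open, it means among the compounds named here.

Of the compounds shown here, two have been measured in a functional assay on A549 cells (Homo sapiens) for inhibition, read by sulforhodamine B assay, with a stated time of 72 h; a lower number here means a stronger inhibitor of growth, a higher number a weaker inhibitor of growth. Compound 1 `CCOC(=O)/C=C/c1ccncc1-c1ccc2c(ccn2C)c1` gives 1720 nM. Compound 2 `COC1CN(C(=O)/C=C/c2ccncc2-c2ccc3ccccc3c2)C1` gives only a limit of the assay, > 10000 nM, not a number. Compound 2 therefore stands at the limit of > 10000 nM in this assay, at which 1 of the 2 values shown sits. For the measured compounds named here, compound 1 and compound 2 differ in more than one place, so no single step between them is counted; their two values show only that compound 1 has a measurable number while compound 2 does not.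

Compound 3 `O=C(/C=C/c1ccncc1-c1ccc2ccccc2c1)NC1CC1` is the compound still to be measured. It differs from compound 2 in one place: cyclopropylamino in place of 3-methoxyazetidin-1-yl on a carbonyl carbon. The amide carbonyl keeps its position; only the group attached to its nitrogen side is exchanged.

Going by the values given here, because compound 2 sits at the limit of > 10000 nM in this assay, at which 1 of the 2 values shown sits, the starting point for compound 3 is itself unknown, and the exchange of one small ring for another gives no recorded step to lean on. The change from compound 2 to compound 3 is expected to amount to an at least 1.1-fold lower number from compound 2 to compound 3 (0.04 log units; that floor lies within the scatter), a modest move at most. Compound 3 is estimated at 9000 nM, within a range from 2500 nM to 30000 nM.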

Compound 3, concentration for 50% growth inhibition: 5840 nM
For compound 3 the middle estimate is 1.5-fold (0.19 log units) above the measured one; the measured number falls inside the stated range.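

For the compounds shown here, on the carbonyl carbon, cyclopropylamino in place of 3-methoxyazetidin-1-yl gives the first step that can be read at this position in this assay, an at least 1.7-fold lower number from compound 2 to compound 3 (0.23 log units; that floor lies within the scatter), and only this floor of the change is known, so its true size could be small or considerably larger. Compound 3 gives a measured number, 5840 nM, which shows that a compound with an amide on this carbonyl carbon can give a value that reads as a plain number. The step has only a floor since the value of compound 2 is a limit and not a number: the limit of > 10000 nM in this assay, at which 1 of the 3 values shown sits.

The exchange alters two things at once, the ring and the hydrogen-bond donor count, and the compounds shown cannot separate these two differences. A methylamino or dimethylamino group on the same carbonyl carbon would help to separate them, while compound 1 differs from compound 3 in more than one place and so cannot settle how the rest of the structure contributes.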